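Chloro for Methoxy at a Second Place, Weighed

A few compounds are considered here, and "the series" means these few. Any claim that something is new, unique, unknown or untested is made for them only; others in the source may bear on it.

Compound 1 `COc1ccccc1/C=C/C(=O)OC/C=C/c1cc(OC)c(OC)cc1OC` gives 50% in a functional assay on the whole organism (strain Kunming) with Mus musculus as the target, with a stated time of 0.5 h, at a dose of 300 mg/kg by the intraperitoneal route; on this read-out higher numbers stand for a weaker effect at the one dose given and lower numbers for a stronger effect. Compound 2 `COc1cc(OC)c(OC)cc1/C=C/COC(=O)/C=C/c1ccccc1Cl` differs from compound 1 by chloro in place of methoxy on an aromatic carbon. In this assay compound 2 gives 25%, so that a number 25 percentage points lower from compound 1 to compound 2 (beyond the scatter). Compound 3 `COc1ccc(/C=C/C(=O)OC/C=C/c2cc(OC)c(OC)cc2OC)cc1` rests on a different core: it differs from compound 1 by 4-methoxyphenyl in place of 2-methoxyphenyl on a double-bonded chain carbon bound to a double-bonded chain carbon, and in this assay compound 3 gives 0%. The steps of a number 50 percentage points lower from compound 1 to compound 3 (beyond the scatter) and a number 25 percentage points lower from compound 2 to compound 3 (beyond the scatter) leave compound 3 with the lowest number of the three. Compound 4 `COc1cc(OC)c(OC)cc1/C=C/COC(=O)/C=C/c1ccc(Cl)cc1` is not yet measured; it differs from compound 3 by chloro in place of methoxy on an aromatic carbon. Among the compounds with values here, this is the same kind of change as the one from compound 1 to compound 2, though not the same: there the place was ortho to a large group, here it is para to a large group. That earlier step lowered the number, but compound 3 already gives 0%, a number that cannot fall further on this read-out. Compound 4 is therefore expected to give about 5%, between 0% and 25%, in this assay. Within the data shown here, the step this estimate means, a number 5 percentage points higher from compound 3 to compound 4 (within the scatter), is expected to be small, with the range open mainly upward; the change at this second place has no measured counterpart here.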

Compound 4, a percentage reported as activity, at one dose (the size of the read-out at that dose, not a potency): 25%
The estimate for compound 4 lay 20 percentage points below the measured number, within the range that was stated.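

In this assay, chloro in place of methoxy did not carry from one core to the other with a single outcome: the same change on two cores in this assay, a number 25 percentage points lower (beyond the scatter) from compound 1 to compound 2 and a number 25 percentage points higher (beyond the scatter) from compound 3 to compound 4, 50 percentage points apart, beyond the scatter of two such steps. The new step reads a number 25 percentage points higher from compound 3 to compound 4 (beyond the scatter), and the two further steps record no change at the digits printed from compound 2 to compound 4 (within the scatter) and a number 25 percentage points lower from compound 1 to compound 4 (beyond the scatter). This shows that, within these four compounds, the size and even the direction of the change cannot be taken from one place to the other, but it does not show why the two steps part, and it gives no rule beyond these two pairs, each of which rests on a single dose.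

The compounds shown hold only methoxy and chloro at these two places, so it remains open how a fluoro group, a methyl group or an amine would read there. Also open, from the compounds shown here alone, is how the same change would read if hydroxy groups replaced the methoxy groups on the other aromatic ring.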